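The compounds below may be only part of what the source reports. "The series", "measured", "known", "first", "only" and "open" are said of these compounds alone.

Measured compounds: compound 1, `CCCCn1cnc2c(Nc3ccccc3)nc(NCOCc3ccc(/C=C/C(=O)Nc4ccccc4N)cc3)nc21`, in a functional assay on HepG2 cells (Homo sapiens) for antiproliferative activity, read by CCK-8 assay, with a stated time of 72 h, tested at 8 uM (a lower number here means a weaker effect, a higher number a stronger effect of the compound at the concentration tested), compound 1 gives 59.3%; compound 2, `Nc1ccccc1NC(=O)c1ccc(Cn2cnc3c(Nc4ccccc4)nc(Cl)nc32)cc1`, gives 74.8%.

Compound 1 thus holds the lower of the two numbers in this assay, and its gap to compound 2 is beyond the usual scatter. Compound 3, `CCCCn1cnc2c(Nc3cccc(Cl)c3)nc(NCOCc3ccc(/C=C/C(=O)Nc4ccccc4N)cc3)nc21`, has not yet been measured in this assay. It differs from compound 1 by chloro in place of hydrogen on an aromatic carbon. Among the measured compounds shown here, no measured pair here shows this change, so only a modest shift is expected: the estimated step of a number 3.7 percentage points higher from compound 1 to compound 3 (within the scatter) leans slightly upward but stays within the scatter. Compound 3 is therefore expected to give 63%, in a range from 48% to 78%.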

Compound 3, a percentage reported as inhibition, at one concentration (the size of the read-out at that concentration, not a potency): 30.4%
The estimate for compound 3 lay 32.6 percentage points above the measured number; measured number outside the range, below it.
By their numbers in this assay, from the lowest: compound 3; then compound 1; then compound 2.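

In this assay, chloro in place of hydrogen on an aromatic carbon, which turns anilino into (3-chlorophenyl)amino, gives a number 28.9 percentage points lower from compound 1 to compound 3 (beyond the scatter). Among the compounds shown here, this is the first single-place step, and it shows that the read-out at this position responds to the addition of one heavy atom. No measurement at hand accounts for the fall. From the compounds shown here alone, it remains open whether fluoro, methoxy or an amine on the same carbon would lower the number as well, or whether the fall is particular to chloro.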